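A few compounds are considered here, and "the series" means these few. Any claim that something is new, unique, unknown or untested is made for them only; others in the source may bear on it.

Working notes on the series. In compound 1 `NS(=O)(=O)CSc1nnc(Br)n1Cc1ccc(Br)c2ccccc12` the sulfonamide nitrogen bears only hydrogen, and in an assay on HEK293 cells for inhibition of solute carrier family 22 member 12 (Homo sapiens) (a lower number here means a stronger inhibitor, a higher number a weaker inhibitor), compound 1 gives 365000 nM. Compound 2 `O=S(=O)(CSc1nnc(Br)n1Cc1ccc(Br)c2ccccc12)Nc1cncc(C(F)(F)F)c1` gives 6380 nM in this assay, and compound 3 `O=S(=O)(CSc1nnc(Br)n1Cc1ccc(Br)c2ccccc12)Nc1ccc(F)nc1` gives 1550 nM in this assay. Compound 2 thus stands second highest of the three numbers, between compound 3 and compound 1. The steps of a 57-fold lower number from compound 1 to compound 2 (1.76 log units; beyond the scatter) and a 240-fold lower number from compound 1 to compound 3 (2.37 log units; beyond the scatter) are both large, while the step of a 4.1-fold lower number from compound 2 to compound 3 (0.61 log units; beyond the scatter) is modest.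

Compound 4 `O=S(=O)(CSc1nnc(Br)n1Cc1ccc(Br)c2ccccc12)Nc1ccc(Br)nc1Br` differs from compound 2 as follows: 2,6-dibromopyridin-3-yl in place of 5-(trifluoromethyl)pyridin-3-yl on a sulfonamide nitrogen. The step that bears on this change is a 4.1-fold lower number from compound 2 to compound 3 (0.61 log units; beyond the scatter), an exchange of one aryl for another on the sulfonamide nitrogen; the large steps from compound 1 concern the addition of an aryl where hydrogen stood and do not apply here. A modest step in this assay is therefore expected for compound 4, with direction uncertain. For compound 4 the estimate is 4000 nM, with a range from 1200 nM to 13000 nM. For compound 4 this estimate means an expected step of a 1.6-fold lower number from compound 2 to compound 4 (0.20 log units; within the scatter).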

Compound 4, half-maximal inhibitory concentration: 5410 nM
For compound 4 the middle estimate is 1.4-fold (0.13 log units) below the measured one; low and high end bracket the measured number.
By their numbers in this assay, from the lowest: compound 3; then compounds 4 and 2 (each within the scatter of the next); then compound 1.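

In this assay, the 2,6-dibromopyridin-3-yl group on the sulfonamide nitrogen keeps the large gain over hydrogen, with a 67-fold lower number from compound 1 to compound 4 (1.83 log units; beyond the scatter). Exchanging the 5-(trifluoromethyl)pyridin-3-yl group for it gives a 1.2-fold lower number from compound 2 to compound 4 (0.07 log units; within the scatter), so these two quite different sets of ring substituents read alike at this position, while a 3.5-fold higher number from compound 3 to compound 4 (0.54 log units; beyond the scatter) shows that the 6-fluoropyridin-3-yl group of compound 3 remains apart from both. Nothing at hand accounts for this grouping of the three aryl substituents.

Still open, from the compounds shown here alone, is how a plain pyridin-3-yl group, or a pyridin-3-yl ring carrying an amine or a carboxylic acid, would read at this nitrogen. A 6-bromopyridin-3-yl group would help separate the kind of halogen from the number of halogens on the ring.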